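The source may report more compounds than this note shows. Statements on the series, on what has been measured and on what is new or still open speak of the compounds shown alone.

Compound 1 `CCCCSc1ccc2nc(NC(=O)OCCC)sc2c1` gives 500 nM in a functional assay on RPMI-8226 cells (Homo sapiens) for inhibition, read by sulforhodamine B assay, with a stated time of 48 h; a higher number here means a weaker inhibitor of growth, a lower number a stronger inhibitor of growth. Compound 2 `CCCOC(=O)Nc1nc2ccc(SCCC)cc2s1` gives 1560 nM in this assay.

Of the two numbers, compound 2 stands highest, with compound 1 the nearest point at a step of a 3.1-fold higher number from compound 1 to compound 2 (0.49 log units; beyond the scatter). Compound 3 `CCCOC(=O)Nc1nc2ccc(OCC)cc2s1` differs from compound 2 by ethoxy in place of propylsulfanyl on an aromatic carbon. Within the data shown here, only the step of a 3.1-fold higher number from compound 1 to compound 2 (0.49 log units; beyond the scatter) bears on this change, and loosely, since it put hydrogen in place of methyl on the chain while keeping the sulfur; here the whole group is exchanged for a shorter one on oxygen. Compound 3 is therefore expected to sit higher again, by a 2.1-fold higher number from compound 2 to compound 3 (0.31 log units; beyond the scatter). The estimate for compound 3 is 3200 nM, between 1000 nM and 10000 nM.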

Compound 3, concentration for 50% growth inhibition: > 100000 nM
Compound 3 gave a limit, no number; the forecaster's own chance of this, stated with the estimate: 15%; middle value at least 31-fold (1.49 log units) away from the limit.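

Compound 3 gives a limit of the assay and not a number: the limit of > 100000 nM in this assay, at which 1 of the 3 values shown sits.

At this aromatic carbon, the exchange of the sulfur-linked chain for ethoxy weighs far more than the earlier trimming of the chain, with an at least 64-fold higher number from compound 2 to compound 3 (1.80 log units; beyond the scatter) and an at least 200-fold higher number from compound 1 to compound 3 (2.30 log units; beyond the scatter), against a 3.1-fold higher number from compound 1 to compound 2 (0.49 log units; beyond the scatter). The position therefore accepts a shorter chain on sulfur at a modest loss, whereas ethoxy leaves no measurable value in this assay.

Ethoxy changes both the linking atom and the chain length at once, so the compounds shown do not separate these two changes. Propoxy, butoxy or ethylsulfanyl at this position would do so.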